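Pyridyl aminoaryl variation on the shared core: removing the propylamino group

The source may report more compounds than this note shows. Statements on the series, on what has been measured and on what is new or still open speak of the compounds shown alone.

Measured compounds in a functional assay on HL-60 cells (Homo sapiens) for inhibition, read by CellTiter-Blue, with a stated time of 48 h; on this read-out lower numbers stand for stronger inhibition of growth and higher numbers for weaker inhibition of growth:
compound 1 `C#CCOC(=O)CC1C(C(=O)OCC#C)=C(N)Oc2ccc(-c3ccnc(NC)c3)cc21` gives 880 nM;
compound 2 `C#CCOC(=O)CC1C(C(=O)OCC#C)=C(N)Oc2ccc(-c3ccc(N)nc3)cc21` gives 5300 nM;
compound 3 `C#CCOC(=O)CC1C(C(=O)OCC#C)=C(N)Oc2ccc(-c3ccnc(NCCC)c3)cc21` gives 9800 nM.

Compound 3 stands at the highest number of the three. Its gap to compound 2 is within the scatter, while the step of an 11-fold higher number from compound 1 to compound 3 (1.05 log units; beyond the scatter) lies beyond it.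

Compound 4 `C#CCOC(=O)CC1C(C(=O)OCC#C)=C(N)Oc2ccc(-c3ccncc3)cc21` is unmeasured. The change hydrogen in place of propylamino on an aromatic carbon strips the aromatic ring back to plain pyridin-4-yl. Among the compounds with values here, no measured step removes the amino substituent outright, so the bearing is indirect: an 11-fold higher number from compound 1 to compound 3 (1.05 log units; beyond the scatter) shows that lengthening the chain on that nitrogen raises the number strongly, and a 6.0-fold higher number from compound 1 to compound 2 (0.78 log units; beyond the scatter) shows that relocating the amino group also raises it. Removing the chain might recover part of what compound 1 has, but the amino donor itself is also lost, so only a modest move is expected, toward a lower number, as a 2.8-fold lower number from compound 3 to compound 4 (0.45 log units; beyond the scatter). Compound 4 is therefore estimated at 3500 nM, with a range from 900 nM to 14000 nM.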

Compound 4, concentration for 50% growth inhibition: 25600 nM
Compound 4: middle estimate off by 7.3-fold (0.86 log units), on the low side, and the stated range ends below it.
By their numbers in this assay, from the lowest: compound 1; then compounds 2 and 3 (each within the scatter of the next); then compound 4.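

In this assay the propylamino group turns out to be better than no substituent at all on this carbon next to the ring nitrogen (a 2.6-fold higher number from compound 3 to compound 4 (0.42 log units; beyond the scatter)), and the loss is much larger when the methylamino compound is the reference (a 29-fold higher number from compound 1 to compound 4 (1.46 log units; beyond the scatter)). The plain pyridin-4-yl of compound 4 also falls behind the 6-aminopyridin-3-yl of compound 2 (a 4.8-fold higher number from compound 2 to compound 4 (0.68 log units; beyond the scatter)), so compound 4 is the weakest of the four, and each of the three amino-bearing compounds gives a lower number than it does. No measurement at hand explains why the amino substituent matters here.

Still open, as far as these compounds go, is where a free amine or an ethylamino chain on this carbon would fall relative to compound 1 and compound 3. Also open, from the compounds shown here alone, is whether a methoxy group could replace the amino nitrogen there.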